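Adding ethyl to the amine of compound 2

A few compounds are considered here, and "the series" means these few. Any claim that something is new, unique, unknown or untested is made for them only; others in the source may bear on it.

Of the compounds shown here, two have been measured so far, compound 1 `CNCC(=O)Nc1cc(OC)ccc1C(=O)c1ccc2c(c1)C=CC(C)(C)O2` and compound 2 `C=C(c1ccc2c(c1)C=CC(C)(C)O2)c1ccc(OC)cc1NC(=O)CN`. In a functional assay on HeLa cells (Homo sapiens) for antiproliferative activity, read by MTT assay, with a stated time of 48 h (on this read-out lower numbers stand for stronger inhibition and higher numbers for weaker inhibition), compound 1 gives 970 nM and compound 2 gives 160 nM. Compound 2 therefore holds the lower of the two numbers, and the gap between them lies beyond the usual scatter.

The next compound is compound 3 `C=C(c1ccc2c(c1)C=CC(C)(C)O2)c1ccc(OC)cc1NC(=O)CNCC`, which has ethyl in place of hydrogen on an amine nitrogen. Among the measured compounds shown here, no measured pair isolates this change, so the data offer no direct precedent for its size. For the measured compounds named here, the only indirect guide is compound 1, the one measured compound with a carbon substituent on that amine nitrogen, at 970 nM. This points cautiously towards weaker inhibition, not stronger. The expected change in this assay is a 2.2-fold higher number from compound 2 to compound 3 (0.34 log units; beyond the scatter), a modest weakening close to the edge of the scatter. For compound 3 the estimated value is 350 nM, with an expected range from 100 nM to 1300 nM.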

Compound 3, half-maximal inhibitory concentration: 1580 nM
Compound 3: the middle estimate sits 4.5-fold (0.65 log units) below what was measured, and the stated range ends below it.
By their numbers in this assay, from the lowest: compound 2; then compounds 1 and 3 (each within the scatter of the next).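

In this assay, among the compounds shown here, this pair gives the first direct reading at the amine nitrogen, and ethyl in place of hydrogen gives a 9.9-fold higher number from compound 2 to compound 3 (0.99 log units; beyond the scatter). The position is therefore sensitive to even a small substituent: the entering group adds only 2 carbon atoms, with no ring, no hydrogen-bond donors or acceptors and no net charge, yet the step lies beyond the scatter. For the compounds shown here, nothing measured so far accounts for the size of this step.

As far as these compounds go, one pair fixes only two points at this nitrogen, so it remains open whether the numbers rise steadily with the size of the substituent or whether ethyl is a special case; methyl on the amine of compound 2, a longer chain such as propyl, and a hydroxyethyl group would each help to separate these readings. Going by these compounds alone, it is also open whether the same change has a similar effect when the carbonyl of compound 1 is present, since no pair isolates it in that setting.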